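The source may hold more compounds than are shown below. What is called first, only, known or untested is meant among the compounds shown, and "the series" means these compounds.

Compound 1 `O=C1C=CC2(C=C1)OCC(=O)N2S(=O)(=O)c1ccccc1`: > 10000 nM
Compound 2 `N#Cc1cccc(S(=O)(=O)N2C(=O)COC23C=CC(=O)C=C3)c1`: > 10000 nM
Compound 3 `O=C1C=CC2(C=C1)OCC(=O)N2S(=O)(=O)c1ccccc1OC(F)(F)F`: > 10000 nM

In a functional assay on MDA-MB-231 cells (Homo sapiens) for inhibition, read by sulforhodamine B assay, with a stated time of 74 h (on this read-out higher numbers stand for weaker inhibition and lower numbers for stronger inhibition), compound 1 gives > 10000 nM, which is a limit of the assay and not a number. Compound 2 gives > 10000 nM, also a limit. Compound 3 gives > 10000 nM, again a limit. The whole set therefore comes down to a single observation: the limit of > 10000 nM in this assay, at which 3 of the 3 values shown sit.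

Compound 4 `O=C1C=CC2(C=C1)OCC(=O)N2S(=O)(=O)c1ccc(C(F)(F)F)cc1` has not yet been measured. It keeps the core of compound 1 and carries trifluoromethyl in place of hydrogen on an aromatic carbon, para to a large group: trifluoromethyl in place of hydrogen on an aromatic carbon.

Two measured changes are of the same kind, a hydrogen on an aromatic carbon giving way to another group. Cyano in place of hydrogen gives a step that the two limits leave unreadable from compound 1 to compound 2, and trifluoromethoxy in place of hydrogen gives a step that the two limits leave unreadable from compound 1 to compound 3. Neither has a readable size, but neither produced a value below the limit. On that basis, no step beyond the usual scatter is expected in this assay, and another limit is the most likely result. The estimate amounts to a number no higher from compound 1 to compound 4 (the limit leaves the size open), an expected step with no clear direction. For compound 4 the estimated value is 10000 nM, with an expected range from 3000 nM to 30000 nM.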

Compound 4, half-maximal inhibitory concentration: 2100 nM
Beside the measured number, compound 4's estimate is 4.8-fold (0.68 log units) above it; the whole stated range lies above it.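

In this assay, for the compounds shown here, trifluoromethyl in place of hydrogen on an aromatic carbon, para to a large group, gives an at least 4.7-fold lower number from compound 1 to compound 4 (0.67 log units; beyond the scatter), the only step in this set whose size can be read. This shows that the core of compound 1 can give a real number on these cells, not just a limit, once this group sits at this place on the aromatic ring. The steps to compound 2 and compound 3 cannot be read, so putting cyano or trifluoromethoxy on the aromatic ring does not by itself give a readable value, and compound 4 stands alone in the set: the limit of > 10000 nM in this assay, at which 3 of the 4 values shown sit.

As far as these compounds go, whether the readable value depends on trifluoromethyl itself, on its place para to the large group, or on both together remains open from one compound. A methyl group, a chlorine atom or an amine at the same place, together with trifluoromethyl at another carbon of the same aromatic ring, would begin to tell these possibilities apart.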